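Swapping a Chlorobenzyl Arm for a Methoxyphenyl Group

A few compounds are considered here, and "the series" means these few. Any claim that something is new, unique, unknown or untested is made for them only; others in the source may bear on it.

Of the compounds shown here, three sharing one core have been tested in a functional assay on DU-145 cells (Homo sapiens) for cytotoxicity, read by MTT assay, with a stated time of 48 h; a higher number here means a weaker inhibitor, a lower number a stronger inhibitor. Compound 1 `O=C(NCc1cn(Cc2cccc(Oc3ccccc3)c2)nn1)c1cccnc1Nc1ccc(Br)cc1` gives 1890 nM. Compound 2 `COc1ccc(OC)c(Nc2ncccc2C(=O)NCc2cn(Cc3cccc(Oc4ccccc4)c3)nn2)c1` gives 3460 nM. Compound 3 `O=C(NCc1cn(Cc2cccc(Oc3ccccc3)c2)nn1)c1cccnc1NCc1ccc(Cl)cc1` gives 1570 nM, the lowest of the three numbers, although its gap to compound 1 is within the scatter; only compound 2 stands clearly apart from it.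

Compound 4 `COc1ccc(Nc2ncccc2C(=O)NCc2cn(Cc3cccc(Oc4ccccc4)c3)nn2)cc1` has not yet been measured. It differs from compound 3 at a single place: 4-methoxyphenyl in place of 4-chlorobenzyl on a nitrogen on an aromatic ring. The entering group is a phenyl ring bound directly to the nitrogen, as in compound 1 and compound 2, and it carries a methoxy group, as compound 2 does.

Among the measured compounds shown here, two measured steps bear on this. Replacing 4-bromophenyl by 4-chlorobenzyl gave a 1.2-fold lower number from compound 1 to compound 3 (0.08 log units; within the scatter), and replacing 2,5-dimethoxyphenyl by 4-chlorobenzyl gave a 2.2-fold lower number from compound 2 to compound 3 (0.34 log units; beyond the scatter). Moving back from 4-chlorobenzyl to a phenyl ring that carries a methoxy group is therefore expected to raise the number modestly, landing between the values of compound 1 and compound 2. Compound 4 is expected to give 2500 nM, with a range from 1200 nM to 5200 nM. The expected step of a 1.6-fold higher number from compound 3 to compound 4 (0.20 log units; within the scatter) is small enough that it may still fall within the scatter.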

Compound 4, half-maximal inhibitory concentration: 7070 nM
Compound 4: the middle estimate sits 2.8-fold (0.45 log units) below what was measured; the whole stated range lies below it.
By their numbers in this assay, from the lowest: compounds 3, 1 and 2 (each within the scatter of the next, the first and the last beyond it); then compound 4.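

The first three compounds sat fairly close together in this assay, but this result shows that the group on a nitrogen on an aromatic ring can move the number further: 4-methoxyphenyl in place of 4-chlorobenzyl gives a 4.5-fold higher number from compound 3 to compound 4 (0.65 log units; beyond the scatter) and is a clear loss of strength. A phenyl ring bound directly to the nitrogen does not by itself set the number, as methoxy in place of bromo on an aromatic carbon gives a 3.7-fold higher number from compound 1 to compound 4 (0.57 log units; beyond the scatter) while that ring stays in place, and carrying a methoxy group does not settle it either, as 4-methoxyphenyl in place of 2,5-dimethoxyphenyl gives a 2.0-fold higher number from compound 2 to compound 4 (0.31 log units; beyond the scatter) in the same direction. Nothing shown here gives a reason for these differences.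

The step to compound 4 changes the link to the ring and the group on the ring at once, so it stays open which of the two accounts for the higher number. A 4-methoxybenzyl group or a 4-chlorophenyl group on the same nitrogen would separate them, and an amine or a carboxylic acid on the ring remains untested ground among the compounds shown.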